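Swapping an Ether Linker for an Alkene at the Pyridine

This account rests on a few compounds, and the source may have more. Where it says the series, first, only, none or still open, it means among the compounds named here.

Three compounds have so far been run through an assay on a protein complex for inhibition of CDK8/Cyclin C (Homo sapiens), with a stated time of 1 h, tested at 10 uM; a higher number here means more inhibition at the concentration tested (going by the name of the read-out), a lower number less inhibition. Compound 1, with the structure `NNC(=O)COc1ccncc1-c1ccc2ccccc2c1`, gives 19%, the lowest of the three numbers. Compound 2, with the structure `O=C(/C=C/c1ccncc1-c1ccc2ncccc2c1)N1CCOCC1`, gives 80%, a reading beyond the scatter above compound 1. Compound 3, with the structure `CCOC(=O)/C=C/c1ccncc1-c1ccc2[nH]ccc2c1`, gives 100%, and again the gap to compound 1 lies beyond the scatter. No two of the measured compounds differ in only one place, so none of these gaps can be pinned to a single change.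

The next compound, compound 4 with the structure `NC(=O)/C=C/c1ccncc1-c1ccc2ccccc2c1`, does differ from compound 1 in a single place: 2-carbamoylethenyl in place of (aminocarbamoyl)methoxy on an aromatic carbon. The ether-linked chain of compound 1 gives way to a chain that is joined through a double bond, the kind of linkage seen in compound 2 and compound 3.

Since compound 2 reaches 80% and compound 3 reaches 100% with such a linkage, the step of a number 46 percentage points higher from compound 1 to compound 4 (beyond the scatter) is expected to be a clear rise, well beyond the scatter. Compound 4 is therefore estimated to give 65%, within a range from 35% to 95%.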

Compound 4, a percentage reported as inhibition, at one concentration (the size of the read-out at that concentration, not a potency): 102%
Compound 4: the middle estimate sits 37 percentage points below what was measured; measured number outside the range, above it.
By their numbers in this assay, from the lowest: compound 1; then compound 2; then compounds 3 and 4 (each within the scatter of the next).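

On the core of compound 1, at the aromatic carbon opposite the ring nitrogen, putting 2-carbamoylethenyl in place of (aminocarbamoyl)methoxy gives a number 83 percentage points higher from compound 1 to compound 4 (beyond the scatter) in this assay. Within the data shown here, none of the earlier compounds differed in only one place, so this is the first sign that a change at this position alone can move the read-out by a large amount. The swap alters several things at once, since the entering chain has one more double bond outside the aromatic rings and fewer hydrogen-bond donors and acceptors than the leaving one, and nothing available explains the rise or tells these changes apart.

The compounds shown leave open whether the double bond or the end of the chain matters more, a question that a saturated chain ending in the same primary amide could help settle. They also leave open how far the end of the chain can vary on this core, for example whether a carboxylic acid or an amine in place of the amide would hold the reading.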